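Moving the Chlorine Around One Phenyl Ring

The source may report more compounds than this note shows. Statements on the series, on what has been measured and on what is new or still open speak of the compounds shown alone.

Measured in an assay on isolated protein for inhibition of DNA topoisomerase 1 (Homo sapiens), with a stated time of 30 min, tested at 100 uM; on this read-out higher numbers stand for a stronger effect at the one concentration tested and lower numbers for a weaker effect:
Compound 1 `Oc1cccc(-c2cc(-c3ccncc3)nc(-c3cccc(Cl)c3)c2)c1` gives 0%
Compound 2 `Oc1cccc(-c2cc(-c3ccccc3)nc(-c3ccc(Cl)cc3)c2)c1` gives 7.1%
Compound 3 `Oc1cccc(-c2cc(-c3ccccc3)nc(-c3ccccc3Cl)c2)c1` gives 3.2%

Compound 3 stands second of these three numbers, but its gaps to compound 1 and to compound 2 both lie within the scatter, so the three cannot be told apart. Compound 4 `Oc1cccc(-c2cc(-c3ccccc3)nc(-c3cccc(Cl)c3)c2)c1` differs from compound 3 in one place: 3-chlorophenyl in place of 2-chlorophenyl on an aromatic carbon. Among the compounds with values here, the only step that bears on this change is the earlier shift of the chlorine on the same ring, a number 3.9 percentage points lower from compound 2 to compound 3 (within the scatter), which stayed within the scatter. A further shift of the chlorine is therefore expected to give no step beyond the scatter, so a number 0.8 percentage points higher from compound 3 to compound 4 (within the scatter) is the expected change. Compound 4 is estimated at 4%, with a range from 0% to 12%.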

Compound 4, a percentage reported as inhibition, at one concentration (the size of the read-out at that concentration, not a potency): 11.5%
Compound 4: the middle estimate sits 7.5 percentage points below what was measured, within the range that was stated.
By their numbers in this assay, from the lowest: compounds 1, 3, 2 and 4 (each within the scatter of the next, the first and the last beyond it).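

Across the three chlorine positions on this ring, a number 8.3 percentage points higher from compound 3 to compound 4 (within the scatter) and a number 4.4 percentage points higher from compound 2 to compound 4 (within the scatter), so in this assay the position of the chlorine makes no readable difference. Within the data shown here, the one step beyond the scatter comes from a different place on the shared core, with 3-chlorophenyl kept: a number 11.5 percentage points higher from compound 1 to compound 4 (beyond the scatter). Nothing available gives a reason for that step.

On these data alone, whether a fluorine, a methoxy group or an amine in place of the chlorine would move the number stays open. So does whether phenyl in place of pyridin-4-yl gives a similar step alongside 2-chlorophenyl or 4-chlorophenyl.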